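A few compounds are considered here, and "the series" means these few. Any claim that something is new, unique, unknown or untested is made for them only; others in the source may bear on it.

Working notes on the series.

Compound 1, `COc1ccc(NC(=O)CN2CCN(c3nnc(Cc4ccccc4)c4ccccc34)CC2)cc1OC`, has no single number in a functional assay on A549 cells (Homo sapiens) for cytotoxicity, read by MTT assay, with a stated time of 72 h; a lower number here means a stronger inhibitor, a higher number a weaker inhibitor: in this assay compound 1 is recorded only as "not active" (no number reported), so its position on the scale cannot be fixed. Among the measured compounds shown here, compound 2, `O=C(CN1CCN(c2nnc(Cc3ccncc3)c3ccccc23)CC1)Nc1cccc(Br)c1`, shares the piperazine-linked amide but carries a different core substituent and a different amide aryl group; in this assay compound 2 gives 1530 nM, the only number so far. For the measured compounds named here, no step between measured compounds can be given, since compound 1 and compound 2 differ in more than one place.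

Compound 3, `O=C(CN1CCN(c2nnc(Cc3ccccc3)c3ccccc23)CC1)Nc1ccc(F)c(C(F)(F)F)c1`, differs from compound 1 in one place: 4-fluoro-3-(trifluoromethyl)phenyl in place of 3,4-dimethoxyphenyl on an amide-type nitrogen. With compound 1 lacking a number, the size of the step in this assay cannot be anchored; the expectation is that compound 3 may move into the measurable range, in the direction of a stronger inhibitor than compound 1, but with wide uncertainty. Compound 3 is estimated at 3500 nM, within a range from 800 nM to 15000 nM.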

Compound 3, half-maximal inhibitory concentration: 2480 nM
Estimate against measurement, compound 3: 1.4-fold (0.15 log units) above, within the range that was stated.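

No step can be read from compound 1 to compound 3: in this assay compound 1 stands only as "not active" (no number reported), with no number, while compound 3 gives 2480 nM. The compounds shown leave open how large the effect of the amide aryl change is. No measured evidence bears on this result.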